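Carbamate series: inverting the fluoromethyl-ethyl stereocentre

A few compounds are considered here, and "the series" means these few. Any claim that something is new, unique, unknown or untested is made for them only; others in the source may bear on it.

Compound 3 `Cc1nc(S(C)(=O)=O)ccc1Oc1ncnc(OC2CCN(C(=O)O[C@H](C)CF)CC2)c1F` gives 196 nM in a functional assay on isolated protein for inhibition of Glucose-dependent insulinotropic receptor (Homo sapiens), read by HTRF and cAMP accumulation (a higher number here means that more compound is needed for the effect, a lower number that less compound is needed), the highest number of the three measured. Compound 1 `Cc1nc(S(C)(=O)=O)ccc1Oc1ncnc(OC2CCN(C(=O)OC(C)C)CC2)c1F` gives 21 nM and compound 2 `Cc1nc(S(C)(=O)=O)ccc1Oc1ncnc(OC2CCN(C(=O)OC(C)F)CC2)c1F` gives 65.5 nM in this assay. The measured steps run a 9.3-fold higher number from compound 1 to compound 3 (0.97 log units; beyond the scatter) and a 3.0-fold higher number from compound 2 to compound 3 (0.48 log units; beyond the scatter); both replace the group on the oxygen next to a carbonyl group rather than its configuration. Compound 4 `Cc1nc(S(C)(=O)=O)ccc1Oc1ncnc(OC2CCN(C(=O)O[C@@H](C)CF)CC2)c1F` differs from compound 3 only thus: the two compounds have the same atoms and bonds and differ only in configuration as drawn: 1 of 1 stereo elements differ; a stereocentre at a saturated chain carbon is drawn R in compound 3 and S in compound 4. No measured step compares two configurations of the same carbamate, so nothing shown bears directly on this change, and either direction is open. A step of a 1.3-fold lower number from compound 3 to compound 4 (0.12 log units; within the scatter) is expected, with wide uncertainty. Compound 4 is estimated at 150 nM, range 40 nM to 600 nM.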

Compound 4, half-maximal effective concentration: 186 nM
Beside the measured number, compound 4's estimate is 1.2-fold (0.09 log units) below it; low and high end bracket the measured number.
By their numbers in this assay, from the lowest: compound 1; then compound 2; then compounds 4 and 3 (each within the scatter of the next).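

In this assay, among the compounds shown here, a 1.1-fold lower number from compound 3 to compound 4 (0.02 log units; within the scatter), so this pair gives the first direct reading of configuration, and the two drawn forms cannot be told apart. The steps of a 2.8-fold higher number from compound 2 to compound 4 (0.45 log units; beyond the scatter) and an 8.9-fold higher number from compound 1 to compound 4 (0.95 log units; beyond the scatter) run close to those of compound 3, so the gap to the earlier carbamates appears with either configuration. The comparison is clean on one point: the fact that compounds 3 and 4 differ only in the configuration as drawn.

Still open, from the compounds shown here alone, is how the two configurations of the 1-fluoroethyl group in compound 2 compare. Also open, going by these compounds, is whether a longer chain or a 1-(trifluoromethyl)ethyl group on that oxygen would separate its configurations.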